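Swapping bromo for methyl on two thiosemicarbazone pairs

This account rests on a few compounds, and the source may have more. Where it says the series, first, only, none or still open, it means among the compounds named here.

Compound 1 `O=C1Nc2ccc(Br)cc2/C1=N/NC(=S)N/N=C/c1ccc(-c2ccccc2)cc1` was tested in a functional assay on COS-7 cells (Chlorocebus aethiops) for inhibition, read by MTT assay (on this read-out lower numbers stand for stronger inhibition and higher numbers for weaker inhibition), and reached only the limit of the assay, > 50000 nM, which is a limit and not a number. Compound 2 `O=C1Nc2ccc(Br)cc2/C1=N/NC(=S)N/N=C/c1c(F)cccc1Cl` gives 2560 nM in this assay, and compound 3 `Cc1ccc2c(c1)/C(=N/NC(=S)N/N=C/c1c(F)cccc1Cl)C(=O)N2` gives 2190 nM. The difference between the cores of compound 1 and compound 2 is not broken down here. Compound 3 differs from compound 2 by methyl in place of bromo on an aromatic carbon, and this change made a 1.2-fold lower number from compound 2 to compound 3 (0.07 log units; within the scatter). The same change, (methyl in place of bromo on an aromatic carbon), leads from compound 1 to the unmeasured compound 4 `Cc1ccc2c(c1)/C(=N/NC(=S)N/N=C/c1ccc(-c3ccccc3)cc1)C(=O)N2`. Since the step seen once stayed within the scatter, compound 4 is expected to show a step that the limit leaves unreadable from compound 1 to compound 4 in this assay, and because of the limit of > 50000 nM in this assay, at which 1 of the 3 values shown sits, it will likely again be reported only as a limit. Compound 4 is therefore estimated at 80000 nM, between 30000 nM and 250000 nM.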

Compound 4, half-maximal inhibitory concentration: > 50000 nM
Compound 4: no number, only a limit; the forecaster's own chance of this, stated with the estimate: 80%; the middle value is on the limit's open side.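

No step can be read between compound 1 and compound 4, because both are reported only as limits, not numbers: the limit of > 50000 nM in this assay, at which 2 of the 4 values shown sit. The compounds shown leave open whether methyl in place of bromo changes inhibition at all in this pair.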